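From an isopropyl ether to a hydroxylated cyclohexyl ether

This account rests on a few compounds, and the source may have more. Where it says the series, first, only, none or still open, it means among the compounds named here.

Among the measured compounds shown here, in a functional assay on CAL-51 cells (Homo sapiens) for antiproliferative activity, read by luminescence and CellTiter-Glo, with a stated time of 3 days (a higher number here means a weaker inhibitor, a lower number a stronger inhibitor), compound 2 (`COc1cc(C(=O)N(C)C)ccc1Nc1nc(OC(C)C)c2cc[nH]c2n1`) gives 1270 nM and holds the higher of the two numbers so far, which makes it the weaker inhibitor. Compound 1 (`CCOc1cc(C(=O)N(C)C)ccc1Nc1nc(O[C@H]2CC[C@@](C)(O)CC2)c2cc[nH]c2n1`) gives 26 nM and so needs a much lower concentration for the same effect.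

Compound 3 (`COc1cc(C(=O)N(C)C)ccc1Nc1nc(O[C@H]2CC[C@@](C)(O)CC2)c2cc[nH]c2n1`) is reached from compound 2 by one change: 4-hydroxy-4-methylcyclohexyl in place of isopropyl on an oxygen on an aromatic ring is the count for putting 4-hydroxy-4-methylcyclohexyl in place of isopropyl on an oxygen on an aromatic ring. For the measured compounds named here, no two measured compounds differ in one place only, so this swap has not yet been seen on its own. The nearest guide is compound 1, which gives 26 nM while carrying the same 4-hydroxy-4-methylcyclohexyl group, although the match with compound 3 is only partial. On that evidence a large gain in strength, beyond the scatter, is expected, with a 32-fold lower number from compound 2 to compound 3 (1.50 log units; beyond the scatter) as the estimated step. For compound 3 the estimated value is 40 nM with an expected range from 14 nM to 120 nM once tested.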

Compound 3, half-maximal inhibitory concentration: 44 nM
The estimate for compound 3 lay 1.1-fold (0.04 log units) below the measured number; the range from low to high includes it.
By their numbers in this assay, from the lowest: compounds 1 and 3 (each within the scatter of the next); then compound 2.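

In this assay the change of isopropyl to 4-hydroxy-4-methylcyclohexyl on an oxygen on an aromatic ring can now be read on its own, and it gives a 29-fold lower number from compound 2 to compound 3 (1.46 log units; beyond the scatter) as a large step in favour of the larger group. This position therefore tolerates much more than a small branched chain, since a six-membered non-aromatic ring carrying a hydroxy and a methyl group gives the far stronger inhibitor of this pair. The second pair puts hydrogen in place of methyl on a saturated chain carbon bound to an oxygen on an aromatic ring, and the result of a 1.7-fold higher number from compound 1 to compound 3 (0.23 log units; within the scatter) means that compound 1 and compound 3 cannot be told apart, so this small change has no visible effect here.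

A plain cyclohexyl group, or an amine on the ring where the hydroxy group stands, would help to show whether the ring or its hydroxy group carries the gain, and the same ring with its two stereocentres reversed would test their arrangement. No measurement shown here explains why the larger group gives the lower number.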